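The source may hold more compounds than are shown below. What is called first, only, known or untested is meant among the compounds shown, and "the series" means these compounds.

Measured so far in an ADME assay on Caco-2 cells (Homo sapiens) for permeability, read by LC-MS, in the apical to basolateral direction, with a stated time of 60 min, at pH 6.5; a lower number here means that the compound crosses the layer more slowly, a higher number that the compound crosses the layer faster:
- compound 1 `O=C(NCc1cc(Cl)ccc1-n1cnnn1)[C@@H]1[C@@H]2C[C@@H]2CN1C(=O)[C@H](O)Cc1ccccn1`: 0.62 10^-6 cm/s
- compound 2 `CCCC[C@@H](O)C(=O)N1C[C@H]2C[C@H]2[C@H]1C(=O)NCc1cc(Cl)ccc1-n1cnnn1`: 33 10^-6 cm/s
- compound 3 `CC(C)(C)[C@@H](O)C(=O)N1C[C@H]2C[C@H]2[C@H]1C(=O)NCc1cc(Cl)ccc1-n1cnnn1`: 3.8 10^-6 cm/s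

Compound 3 is second highest of these three numbers. Its two neighbours are separated from it by a 6.1-fold higher number from compound 1 to compound 3 (0.79 log units; beyond the scatter) and an 8.7-fold lower number from compound 2 to compound 3 (0.94 log units; beyond the scatter).

Compound 4 `O=C(NCc1cc(Cl)ccc1-n1cnnn1)[C@@H]1[C@@H]2C[C@@H]2CN1C(=O)[C@H](O)c1ccccc1F` is the next to be read. It carries 2-fluorophenyl in place of tert-butyl on a saturated chain carbon bound to a carbonyl carbon and an oxygen on a saturated carbon.

Among the compounds with values here, no measured step makes this exchange, and no measured compound has a ring of carbon only on this chain. The nearest evidence is indirect. Changing the group on this chain has already moved the number widely, with a 53-fold higher number from compound 1 to compound 2 (1.73 log units; beyond the scatter) as the largest step. Within the data shown here, the only measured compound with a ring in this part of the structure is compound 1, at 0.62 10^-6 cm/s, and its ring is pyridin-2-yl rather than a ring of carbon only. Those steps point in no single direction for compound 4, so the expectation stays close to compound 3 at 3.8 10^-6 cm/s, with a slight lean upward and a wide range. The expected step is a 1.8-fold higher number from compound 3 to compound 4 (0.27 log units; within the scatter), and no step beyond the scatter is expected. The estimated value for compound 4 is 7 10^-6 cm/s, with an expected range from 2.5 10^-6 cm/s to 20 10^-6 cm/s.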

Compound 4, apparent permeability: 2.3 10^-6 cm/s
Estimate against measurement, compound 4: 3.0-fold (0.48 log units) above; the measured number lies below the stated range.
By their numbers in this assay, from the lowest: compound 1; then compounds 4 and 3 (each within the scatter of the next); then compound 2.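

In this assay, a ring of carbon only on this chain carbon cannot be told apart from tert-butyl: a 1.7-fold lower number from compound 3 to compound 4 (0.22 log units; within the scatter), although 2-fluorophenyl brings 7 heavy atoms in place of 4. The same exchange set against the other two groups gives a 14-fold lower number from compound 2 to compound 4 (1.16 log units; beyond the scatter) and a 3.7-fold higher number from compound 1 to compound 4 (0.57 log units; beyond the scatter), which places compound 4 with compound 3, clearly under the butyl of compound 2 and clearly over the (pyridin-2-yl)methyl of compound 1, so carrying a ring on this chain does not by itself give a number as low as that of compound 1. Nothing available bears on why these groups read as they do.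

Compound 1 differs from compound 4 both in the ring atoms and in the extra chain carbon, and the compounds shown do not separate these two differences; a benzyl group or a pyridin-2-yl bound directly to the same carbon would each change only one of them. From the compounds shown here alone, whether the high number of compound 2 belongs to unbranched chains in general stays open too, since a propyl or a pentyl chain at this place would be needed to show it.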